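Swapping nitro for cyano on the shared core

The compounds below may be only part of what the source reports. "The series", "measured", "known", "first", "only" and "open" are said of these compounds alone.

Compound 1 `Oc1cccc2cc(-c3ccccc3)ccc12` carries hydrogen at the place that is varied across this set. In an assay for binding affinity to 17-beta-hydroxysteroid dehydrogenase type 1 (Homo sapiens), with a stated time of 20 min, tested at 1 uM (on this read-out lower numbers stand for less inhibition and higher numbers for more inhibition at the one concentration tested (going by the name of the read-out)), compound 1 gives < 10%, which is a limit of the assay rather than a number. Compound 2 `OCc1ccc(-c2ccc3c(O)cccc3c2)cc1` gives 14% and compound 3 `O=[N+]([O-])c1ccc(-c2ccc3c(O)cccc3c2)cc1` gives 15%. Of the two numbers shown, compound 3 is the higher, with compound 2 nearest, but a number 1 percentage points higher from compound 2 to compound 3 (within the scatter) lies within the scatter. The step of a number at least 5 percentage points higher from compound 1 to compound 3 (that floor lies within the scatter) starts from a limit (the limit of < 10% in this assay, at which 1 of the 3 values shown sits), so even its floor sits within the scatter.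

Compound 4 `N#Cc1ccc(-c2ccc3c(O)cccc3c2)cc1` differs from compound 3 by cyano in place of nitro on an aromatic carbon. Among the compounds with values here, no measured step exchanges these two groups; the closest evidence is a number at least 4 percentage points higher from compound 1 to compound 2 (that floor lies within the scatter) and a number 1 percentage points higher from compound 2 to compound 3 (within the scatter), neither of which rises beyond the scatter. One therefore expects no step beyond the scatter, and a number 1 percentage points lower from compound 3 to compound 4 (within the scatter) is the estimated step. Compound 4 is expected to give 14%, estimated to lie between 5% and 25%.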

Compound 4, a percentage reported as inhibition, at one concentration (the size of the read-out at that concentration, not a potency): 16%
Compound 4: the middle estimate sits 2 percentage points below what was measured; the range from low to high includes it.
By their numbers in this assay, from the lowest: compounds 2, 3 and 4 (each within the scatter of the next). At a limit, below all of these: compound 1.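

Cyano in place of nitro gives, in this assay, a number 1 percentage points higher from compound 3 to compound 4 (within the scatter), so these two groups cannot be told apart at this position, para to a large group, even though they differ in heavy atoms and bond type. The same holds for cyano in place of hydroxymethyl, with a number 2 percentage points higher from compound 2 to compound 4 (within the scatter), so all three substituted compounds now lie within the scatter of one another. The comparison with hydrogen gives only a floor, with a number at least 6 percentage points higher from compound 1 to compound 4 (that floor lies within the scatter), because that step starts from a limit: the limit of < 10% in this assay, at which 1 of the 4 values shown sits.

The compounds shown leave open whether any group at this position can raise the inhibition beyond the scatter. An amine or a carboxylic acid in the same place would put that question to a different kind of group.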